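Replacing 2-fluoro-5-nitrophenyl with 4-acetylphenyl on the amide

The source may hold more compounds than are shown below. What is called first, only, known or untested is meant among the compounds shown, and "the series" means these compounds.

Among the measured compounds shown here, in a functional assay on A549 cells (Homo sapiens) for cytotoxicity, read by MTT assay (a lower number here means a stronger inhibitor, a higher number a weaker inhibitor), compound 3 `CCn1cc(C(=O)Nc2cc([N+](=O)[O-])ccc2F)c(=O)c2cc(F)c(N3CCNC(C)C3)c(F)c21` has the lowest number of the three measured so far, at 1700 nM in this series. Compound 2 `CCn1cc(C(=O)Nc2ccc(C)c([N+](=O)[O-])c2)c(=O)c2cc(F)c(N3CCNC(C)C3)c(F)c21` stands at 3700 nM and compound 1 `CCn1cc(C(=O)Nc2ccccc2)c(=O)c2cc(F)c(N3CCNC(C)C3)c(F)c21` at 39300 nM on the same core. The next entry is compound 4 `CCn1cc(C(=O)Nc2ccc(C(C)=O)cc2)c(=O)c2cc(F)c(N3CCNC(C)C3)c(F)c21`, with 4-acetylphenyl in place of 2-fluoro-5-nitrophenyl on an amide-type nitrogen. For the measured compounds named here, three measured steps bear on this change. Replacing phenyl gave an 11-fold lower number from compound 1 to compound 2 (1.03 log units; beyond the scatter) and a 23-fold lower number from compound 1 to compound 3 (1.36 log units; beyond the scatter) and both are large. Exchanging one nitro-bearing group for the other gave only a 2.2-fold lower number from compound 2 to compound 3 (0.34 log units; beyond the scatter) and that step is modest. Going by the values given here, no measured compound carries an acetyl group, so the steps offer only a rough guide. Compound 4 also has no nitro group, and part of the drop seen in a 23-fold lower number from compound 1 to compound 3 (1.36 log units; beyond the scatter) is expected to be lost. The expected step is a 5.3-fold higher number from compound 3 to compound 4 (0.72 log units; beyond the scatter) and it is a rise of moderate to large size. For compound 4 the estimated value is 9000 nM (range 2500 nM to 30000 nM).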

Compound 4, half-maximal inhibitory concentration: 4000 nM
Beside the measured number, compound 4's estimate is 2.3-fold (0.35 log units) above it, within the range that was stated.
By their numbers in this assay, from the lowest: compound 3; then compounds 2 and 4 (each within the scatter of the next); then compound 1.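

In this assay, a nitro group is not needed for a substantial drop in number at this amide-type nitrogen: acetyl in place of hydrogen on an aromatic carbon gives a 9.8-fold lower number from compound 1 to compound 4 (0.99 log units; beyond the scatter). The 4-acetylphenyl and 4-methyl-3-nitrophenyl groups cannot be told apart here, with a 1.1-fold higher number from compound 2 to compound 4 (0.03 log units; within the scatter), while the change from 2-fluoro-5-nitrophenyl to 4-acetylphenyl costs only a modest amount, with a 2.4-fold higher number from compound 3 to compound 4 (0.37 log units; beyond the scatter). No measurement shown accounts for these steps.

As far as these compounds go, it remains open whether the carbonyl of the acetyl group matters, and an amine, a carboxylic acid or a methoxy group in its place on the phenyl ring would test this. Also open, from the compounds shown here alone, is whether a fluorine added to the 4-acetylphenyl group would lower the number further, as the fluoro-bearing nitrophenyl of compound 3 might suggest.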